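Removing the Hydroxy Group from Compound 2

This account rests on a few compounds, and the source may have more. Where it says the series, first, only, none or still open, it means among the compounds named here.

In an ADME assay on HEK293 cells (Homo sapiens) for cytotoxicity, read by MTT assay, with a stated time of 72 h (on this read-out lower numbers stand for stronger inhibition and higher numbers for weaker inhibition), compound 1 `COc1ccc(C2=C(c3cc(OC)c(OC)c(OC)c3)C(=O)C(OC(C)=O)C2)cc1F` gives 59 ug/mL. Compound 2 `COc1ccc(C2=C(c3cc(OC)c(OC)c(OC)c3)C(=O)CC2O)cc1O` stands at > 100 ug/mL in this assay, which is a limit of the assay and not a number. Compound 3 `COc1ccc(C2=C(c3cc(OC)c(OC)c(OC)c3)C(=O)CC2O)cc1` has hydrogen in place of hydroxy on an aromatic carbon, ortho to a methoxy group, turning 3-hydroxy-4-methoxyphenyl into 4-methoxyphenyl (hydrogen in place of hydroxy on an aromatic carbon). Among the measured compounds shown here, no measured step shows what such a change does here. A modest shift toward stronger inhibition is expected, an at least 1.2-fold lower number from compound 2 to compound 3 (0.09 log units; that floor lies within the scatter), and it may stay within the scatter. For compound 3 the estimated value is 80 ug/mL, with an expected range from 35 ug/mL to 150 ug/mL.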

Compound 3, half-maximal inhibitory concentration: 10 ug/mL
Compound 3: middle estimate off by 8.0-fold (0.90 log units), on the high side; the measured number lies below the stated range.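

In this assay, the 3-hydroxy-4-methoxyphenyl to 4-methoxyphenyl change gives an at least 10-fold lower number from compound 2 to compound 3 (1.00 log units; beyond the scatter), so this aromatic carbon, ortho to a methoxy group, clearly matters to the read-out. The hydroxy group marks the weaker compound of this pair, and hydrogen the stronger one. The full size of the step remains unknown because compound 2 stands at a limit of the assay and not at a number: the limit of > 100 ug/mL in this assay, at which 1 of the 3 values shown sits.

From the compounds shown here alone, whether an amine or a chlorine atom on this carbon would behave like hydrogen or like hydroxy remains open. The compounds shown also leave open whether the step would hold with a different group on the other aromatic ring.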